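The source may report more compounds than this note shows. Statements on the series, on what has been measured and on what is new or still open speak of the compounds shown alone.

Measured so far:
- Compound 1 `COc1cc(-c2nnc3n2NC(c2ccco2)C(C(=O)c2ccccc2C)S3)cc(OC)c1OC`: 80000 nM
- Compound 2 `COc1cc(C(=O)C2Sc3nnc(-c4cc(OC)c(OC)c(OC)c4)n3NC2c2ccco2)cc(OC)c1OC`: 48300 nM
- Compound 3 `COc1cc(-c2nnc3n2NC(c2ccco2)C(C(=O)c2ccccc2F)S3)cc(OC)c1OC`: 78700 nM

In a functional assay on A549 cells (Homo sapiens) for cytotoxicity, read by MTT assay, with a stated time of 48 h (on this read-out higher numbers stand for weaker inhibition and lower numbers for stronger inhibition), the three compounds give numbers that all lie within the scatter of one another: a 1.0-fold lower number from compound 1 to compound 3 (0.01 log units; within the scatter) and a 1.6-fold higher number from compound 2 to compound 3 (0.21 log units; within the scatter). Compound 3 therefore stands neither apart from compound 1 nor from compound 2.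

Compound 4 `COc1cc(-c2nnc3n2NC(c2ccco2)C(C(=O)c2ccc(Br)cc2)S3)cc(OC)c1OC` differs from compound 3 in one place: 4-bromophenyl in place of 2-fluorophenyl on a carbonyl carbon. Every measured step here also swaps the aryl group on that carbonyl carbon, and each stayed within the scatter: a 1.7-fold lower number from compound 1 to compound 2 (0.22 log units; within the scatter), a 1.6-fold higher number from compound 2 to compound 3 (0.21 log units; within the scatter), and the fluoro-for-methyl swap a 1.0-fold lower number from compound 1 to compound 3 (0.01 log units; within the scatter). On that basis no step beyond the scatter is expected, a 1.0-fold higher number from compound 3 to compound 4 (0.01 log units; within the scatter). Compound 4 is estimated at 80000 nM, with a range from 30000 nM to 200000 nM.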

Compound 4, half-maximal inhibitory concentration: 42100 nM
Compound 4: middle estimate off by 1.9-fold (0.28 log units), on the high side; the measured number falls inside the stated range.
By their numbers in this assay, from the lowest: compounds 4, 2, 3 and 1 (each within the scatter of the next).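

In this assay the step to a bromine-bearing aryl group on this carbonyl carbon is again small: a 1.9-fold lower number from compound 3 to compound 4 (0.27 log units; within the scatter) and a 1.1-fold lower number from compound 2 to compound 4 (0.06 log units; within the scatter) and a 1.9-fold lower number from compound 1 to compound 4 (0.28 log units; within the scatter) all stay within the scatter. Four different aryl groups at this position therefore give numbers that cannot be told apart, so swapping 2-fluorophenyl for 4-bromophenyl adds no measurable change. No measurement on hand bears on why these numbers sit so close.

On these data alone, whether an amine or a carboxylic acid on this aryl ring would move the number beyond the scatter stays open. So does the outcome of a saturated alkyl chain in place of the aryl group.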